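Trimethoxyphenyl ureas and sulfinamides: Daoy cytotoxicity notes

This account rests on a few compounds, and the source may have more. Where it says the series, first, only, none or still open, it means among the compounds named here.

Measured so far:
compound 1, `COc1ccc(N(C)C(=O)N(C)c2cc(OC)c(OC)c(OC)c2)cc1`, >= 125000 nM
compound 2, `COc1ccc([S+]([O-])N(C)c2cc(OC)c(OC)c(OC)c2)cc1`, >= 125000 nM

In a functional assay on Daoy cells (Homo sapiens) for cytotoxicity, read by MTT assay, with a stated time of 72 h (a lower number here means a stronger inhibitor, a higher number a weaker inhibitor), compound 1 returns only a limit, >= 125000 nM, not a number. Compound 2 likewise reaches only a limit in this assay, >= 125000 nM. For the measured compounds named here, both values therefore sit at the same boundary, as the limit of >= 125000 nM in this assay, at which 2 of the 2 values shown sit, records, and no real step between them can be read.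

Compound 3, `COc1cc(N(C)C(=O)N(C)c2cccc(F)c2)cc(OC)c1OC`, is not yet measured. It differs from compound 1 by 3-fluorophenyl in place of 4-methoxyphenyl on an amide-type nitrogen; the shared core is otherwise unchanged. Going by the values given here, with compound 1 showing no number in this assay, only the limit, there is no measured step from which to size the change. The expectation is that compound 3 stays at or near the same limit, so the step of a number no higher from compound 1 to compound 3 (the limit leaves the size open) is expected to be none beyond the scatter. Compound 3 is thus estimated at 125000 nM in this assay, with a range from 30000 nM to 500000 nM, because compound 1 already sits at the limit of >= 125000 nM in this assay, at which 2 of the 2 values shown sit.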

Compound 3, half-maximal inhibitory concentration: >= 125000 nM
Compound 3: no number, only a limit; the forecaster's own chance of this, stated with the estimate: 80%; the middle value lies on the limit itself.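

Compound 1 and compound 3 give no readable step in this assay, since each returns only a limit: the limit of >= 125000 nM in this assay, at which 3 of the 3 values shown sit.

The compounds shown leave open whether 3-fluorophenyl and 4-methoxyphenyl differ at all in this assay on this shared core, since no actual number is available for either.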